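Aryloxy cyclohexyl ureas: trifluoromethyl to fluoro swap

The source may report more compounds than this note shows. Statements on the series, on what has been measured and on what is new or still open speak of the compounds shown alone.

compound 1 `O=C(Nc1cccc(C(F)(F)F)c1)N[C@H]1CC[C@H](Oc2cccc(C(F)(F)F)c2)CC1` gives 1300 nM in a functional assay on CRL2813 cells (Homo sapiens) for cytotoxicity, read by sulforhodamine B assay, with a stated time of 5 days; a lower number here means a stronger inhibitor, a higher number a weaker inhibitor
compound 2 `O=C(Nc1cccc(C(F)(F)F)c1)N[C@H]1CCC[C@H](Oc2ccc(C(F)(F)F)cc2)C1` gives 3800 nM in this assay
compound 3 `Cc1ccccc1NC(=O)N[C@H]1CC[C@H](Oc2ccc(F)cc2)CC1` shows > 20000 nM in this assay, which is a limit of the assay and not a number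

Compound 1 holds the lowest of the two numbers; compound 2 sits higher by a gap beyond the usual scatter. Compound 4 `O=C(Nc1cccc(C(F)(F)F)c1)N[C@H]1CC[C@H](Oc2ccccc2F)CC1` is not yet measured. It differs from compound 1 by 2-fluorophenyl in place of 3-(trifluoromethyl)phenyl on an oxygen on a saturated carbon. For the measured compounds named here, no measured pair isolates this change. Compound 3 also carries a fluorophenyl on the oxygen, beside a different urea, and reaches only (the limit of > 20000 nM in this assay, at which 1 of the 3 values shown sits). The expected step of a 3.8-fold higher number from compound 1 to compound 4 (0.59 log units; beyond the scatter) goes toward a higher number, beyond the scatter. Compound 4 is estimated at 5000 nM, within 1500 nM to 20000 nM.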

Compound 4, half-maximal inhibitory concentration: 2450 nM
Estimate against measurement, compound 4: 2.0-fold (0.31 log units) above; the range from low to high includes it.
By their numbers in this assay, from the lowest: compounds 1, 4 and 2 (each within the scatter of the next, the first and the last beyond it). At a limit, above all of these: compound 3.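

In this assay the change reads as a 1.9-fold higher number from compound 1 to compound 4 (0.28 log units; within the scatter) and gives the first direct view of this position. On an oxygen on a saturated carbon, 2-fluorophenyl takes the place of 3-(trifluoromethyl)phenyl with the two compounds within the scatter of each other, so trifluoromethyl on this ring is not required to stay at this level. Compound 3 differs from compound 4 in more than one place, no step can be read between them, and its value is a limit of the assay: the limit of > 20000 nM in this assay, at which 1 of the 4 values shown sits.

As far as these compounds go, an amine or a carboxylic acid on this phenyl ring, or a longer chain in its place, remains open.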